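The source may report more compounds than this note shows. Statements on the series, on what has been measured and on what is new or still open speak of the compounds shown alone.

Working notes on the series. Two compounds have a maximal response in a functional assay on CHO cells for agonist activity at Free fatty acid receptor 1 (Homo sapiens), read by a luciferase reporter (a higher number here means a larger maximal response, a lower number a smaller maximal response), so far. Compound 1 `O=C(O)c1ccc(NCc2cccc(Oc3ccccc3)c2)cc1` gives 86%, the lower of the two numbers, and compound 2 `Cc1nc(-c2ccc(C(F)(F)F)cc2)sc1CNc1ccc(/C=C/C(=O)O)cc1` gives 95%; the gap between them lies within the scatter. Compound 3 `CC(C)NC(=O)CCc1ccc(NCc2cccc(Oc3ccccc3)c2)cc1` differs from compound 1 by 2-(isopropylcarbamoyl)ethyl in place of carboxy on an aromatic carbon. For the measured compounds named here, no measured pair covers a change of this kind, so the size of the step is open. A drop beyond the scatter is expected, a number 41 percentage points lower from compound 1 to compound 3 (beyond the scatter), starting from the response of compound 1 at 86%. Compound 3 is estimated at 45%, within a range from 10% to 85%.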

Compound 3, largest response reached (reported as percent of maximum), in percent of the reference or control that the assay uses: 66%
Beside the measured number, compound 3's estimate is 21 percentage points below it; measured number inside the range.
By their numbers in this assay, from the lowest: compound 3; then compounds 1 and 2 (each within the scatter of the next).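

At the aromatic carbon para to a large group, carboxy is not needed for a response in this assay: with 2-(isopropylcarbamoyl)ethyl in its place there is a number 20 percentage points lower from compound 1 to compound 3 (beyond the scatter), and compound 3 still gives 66%. The loss is therefore beyond the scatter but only partial. Nothing at hand bears on why the response falls.

This change alters both the chain and its end group, so the compounds shown leave open which of the two carries the step. A carboxylic acid on the same ethyl chain, or a primary amide there, would separate them.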